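The source may hold more compounds than are shown below. What is called first, only, known or untested is meant among the compounds shown, and "the series" means these compounds.

Compound 3 `COc1ccccc1-c1c(C)nn(-c2nc(-c3ccc(Cl)c(Cl)c3)c(SC(C)C)s2)c1C(=O)O` gives 14700 nM in a functional assay on BJAB cells (Homo sapiens) for antiproliferative activity, with a stated time of 4 days (on this read-out lower numbers stand for an effect already at smaller amounts and higher numbers for an effect only at larger amounts of compound), the highest of the two numbers at hand. Compound 2 `Cc1nn(-c2nc(-c3ccc(Cl)c(Cl)c3)c(SC(C)C)s2)c(C(=O)O)c1-c1ccc(Cl)cc1` gives 2500 nM, and the step of a 5.9-fold higher number from compound 2 to compound 3 (0.77 log units; beyond the scatter) separates the pair. Compound 1 `Cc1c(-c2cc(Cl)cc(Cl)c2)c(C(=O)O)nn1-c1nc(-c2cccnc2)c(SC(C)C)s1` is recorded as "not active" (no number reported), with no number reported. Compound 4 `Cc1nn(-c2nc(-c3ccc(Cl)c(Cl)c3)c(SC(C)C)s2)c(C(=O)O)c1Cc1ccccc1[N+](=O)[O-]` differs from compound 3 by 2-nitrobenzyl in place of 2-methoxyphenyl on an aromatic carbon. Within the data shown here, the one measured step at this position, a 5.9-fold higher number from compound 2 to compound 3 (0.77 log units; beyond the scatter), swapped 4-chlorophenyl for 2-methoxyphenyl; no measured step covers a 2-nitrobenzyl group, so its bearing is indirect and weak. A step of a 1.5-fold lower number from compound 3 to compound 4 (0.17 log units; within the scatter) in this assay is therefore expected, not beyond the scatter. Compound 4 is estimated at 10000 nM, with a range from 3000 nM to 40000 nM.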

Compound 4, half-maximal effective concentration: 20000 nM
For compound 4 the middle estimate is 2.0-fold (0.30 log units) below the measured one; low and high end bracket the measured number.
By their numbers in this assay, from the lowest: compound 2; then compounds 3 and 4 (each within the scatter of the next).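

In this assay, putting 2-nitrobenzyl in place of 2-methoxyphenyl gives a 1.4-fold higher number from compound 3 to compound 4 (0.13 log units; within the scatter), so these two groups cannot be told apart at this position. Against 4-chlorophenyl, the same group gives an 8.0-fold higher number from compound 2 to compound 4 (0.90 log units; beyond the scatter), making it the second group here to separate from 4-chlorophenyl beyond the scatter. Nothing at hand gives a reason for either step.

Still open, on these data alone, is how an unsubstituted phenyl or a 4-methoxyphenyl group would read at this position. A benzyl group carrying an amine in place of the nitro group is equally untested in these compounds.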